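The source may report more compounds than this note shows. Statements on the series, on what has been measured and on what is new or still open speak of the compounds shown alone.

Measured compounds:
compound 1 `O=C1N=C(C2C(=O)c3ccccc3C2=O)CC(c2ccccc2[N+](=O)[O-])N1` — 11%
compound 2 `O=C1N=C(C2C(=O)c3ccccc3C2=O)CC(c2ccccc2)N1` — 20%

In a functional assay on the whole organism for inhibition, with Rattus norvegicus as the target, read by paw edema, with stated times of 30 min and 1 h, at a dose of 10 mg/kg by the oral route (a higher number here means more inhibition at the dose given (going by the name of the read-out), a lower number less inhibition), compound 1 gives 11% and compound 2 gives 20%. For the measured compounds named here, the single measured step, hydrogen in place of nitro on an aromatic carbon, is a number 9 percentage points higher from compound 1 to compound 2 (within the scatter). Compound 2 therefore stands beside compound 1 rather than apart from it, the two numbers separated only by a step within the scatter.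

Compound 3 `COc1ccc(C2CC(C3C(=O)c4ccccc4C3=O)=NC(=O)N2)cc1` has not been measured in this assay. It differs from compound 2 by methoxy in place of hydrogen on an aromatic carbon. Going by the values given here, no measured step involves a methoxy group, so the only guide is the step from compound 1 to compound 2, which shows that a change on this aromatic ring moved the read-out by no more than the scatter. The expectation is that the step of no change at the digits printed from compound 2 to compound 3 (within the scatter) likewise stays within the scatter. Compound 3 is estimated at 20%, with a range from 8% to 34%.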

Compound 3, a percentage reported as inhibition, in the whole organism at one dose (the size of the read-out at that dose, not a potency): 22%
The estimate for compound 3 lay 2 percentage points below the measured number, and the stated range covers the measured number.
By their numbers in this assay, from the lowest: compounds 1, 2 and 3 (each within the scatter of the next, the first and the last beyond it).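

Placing methoxy on the aromatic carbon para to a large group gives a number 2 percentage points higher from compound 2 to compound 3 (within the scatter) in this assay, so at this place the methoxy compound cannot be told apart from the unsubstituted phenyl compound. For the compounds shown here, the change from 2-nitrophenyl to 4-methoxyphenyl gives a number 11 percentage points higher from compound 1 to compound 3 (beyond the scatter), the first step in this small set to pass beyond the scatter, although compound 2 stays within the scatter of both compounds. Nothing available accounts for these numbers.

Going by these compounds, whether the modest gap follows the group or its place on the ring remains open, since 2-nitrophenyl and 4-methoxyphenyl differ in both. The compounds shown also leave open how an amine, a carboxylic acid or a longer alkoxy chain on this carbon would compare with hydrogen and methoxy.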